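Methoxy in place of nitro on compound 2

The source may report more compounds than this note shows. Statements on the series, on what has been measured and on what is new or still open speak of the compounds shown alone.

Compound 1 `O=C(/C=C/c1ccc(Cl)cc1)N1CCC=CS1(=O)=O` gives 26400 nM in a functional assay on HeLa cells (Homo sapiens) for inhibition, read by sulforhodamine B assay, with a stated time of 48 h; on this read-out lower numbers stand for stronger inhibition of growth and higher numbers for weaker inhibition of growth. Compound 2 `O=C(/C=C/c1ccc([N+](=O)[O-])cc1)N1CCC=CS1(=O)=O` gives 24400 nM in this assay, and compound 3 `O=C(c1cccc(Cl)c1)N1CCC=CS1(=O)=O` gives 45400 nM; all three numbers lie within the usual scatter of one another, so compound 2 cannot be set apart from the others on these data. Compound 4 `COc1ccc(/C=C/C(=O)N2CCC=CS2(=O)=O)cc1` differs from compound 2 by methoxy in place of nitro on an aromatic carbon. Among the compounds with values here, the one measured step that bears on such an exchange at this place is a 1.1-fold lower number from compound 1 to compound 2 (0.03 log units; within the scatter), a swap of one para substituent for another that left the number essentially unchanged. A step of similar size, that is none beyond the scatter, is therefore expected for a 1.0-fold higher number from compound 2 to compound 4 (0.01 log units; within the scatter). Compound 4 is estimated at 25000 nM, with a range from 12000 nM to 50000 nM.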

Compound 4, concentration for 50% growth inhibition: 24400 nM
For compound 4 the middle estimate is 1.0-fold (0.01 log units) above the measured one, and the stated range covers the measured number.
By their numbers in this assay, from the lowest: compounds 2, 4, 1 and 3 (each within the scatter of the next).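

In this assay methoxy in place of nitro gives no change at the digits printed from compound 2 to compound 4 (within the scatter) and methoxy in place of chloro gives a 1.1-fold lower number from compound 1 to compound 4 (0.03 log units; within the scatter). Chloro, nitro and methoxy, all on the aromatic carbon para to a large group, now lie within the scatter of one another, so this place has tolerated three different groups, where compound 1 and compound 2 alone gave only one exchange. No measurement on hand accounts for this lack of separation. As far as these compounds go, whether an amine, a carboxylic acid or a longer chain at this place would move the number beyond the scatter remains open.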